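Capping the Phenol: From Compound 2 to Compound 3

A few compounds are considered here, and "the series" means these few. Any claim that something is new, unique, unknown or untested is made for them only; others in the source may bear on it.

Compound 1, `COc1cccc(CCCNC(C)=O)c1`: 0.751 nM
Compound 2, `COc1ccc(O)c(CCCNC(C)=O)c1`: 46.2 nM

Of the compounds shown here, two have been measured in an assay on CHO cells for displacement of a labelled ligand from melatonin receptor type 1B (Homo sapiens), read by scintillation counting, with a stated time of 60 min; on this read-out lower numbers stand for stronger inhibition and higher numbers for weaker inhibition. On these two numbers compound 2 stands highest, and its nearest neighbour is compound 1. Among the measured compounds shown here, the single step between them, a 62-fold higher number from compound 1 to compound 2 (1.79 log units; beyond the scatter), came with hydroxy in place of hydrogen on an aromatic carbon.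

Compound 3 `CCCOc1ccc(OC)cc1CCCNC(C)=O` has not yet been measured in this assay. It differs from compound 2 by propyl in place of hydrogen on an oxygen on an aromatic ring; cut one bond further out, the change reads hydroxy to propoxy. For the measured compounds named here, no measured step touches that oxygen, so the only guide is a 62-fold higher number from compound 1 to compound 2 (1.79 log units; beyond the scatter), which shows how large a swing the free hydroxy brought about. Going by these compounds, whether capping that oxygen with propyl pulls the number back toward compound 1 is untested. Compound 3 is therefore expected to give 8 nM, somewhere between 1 nM and 80 nM. The implied step a 5.8-fold lower number from compound 2 to compound 3 (0.76 log units; beyond the scatter) is an estimate leaning toward lower numbers, with wide uncertainty.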

Compound 3, inhibition constant: 2.12 nM
Beside the measured number, compound 3's estimate is 3.8-fold (0.58 log units) above it, and the stated range covers the measured number.
By their numbers in this assay, from the lowest: compound 1; then compound 3; then compound 2.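

In this assay, putting propyl on the oxygen on the aromatic ring recovers most of the loss that came with the free hydroxy, giving a 22-fold lower number from compound 2 to compound 3 (1.34 log units; beyond the scatter), so a group at this position need not carry that loss. The recovery is not complete, since propoxy in place of hydrogen on the aromatic carbon still gives a 2.8-fold higher number from compound 1 to compound 3 (0.45 log units; beyond the scatter), a modest step but one beyond the scatter. Nothing at hand explains the difference between the free hydroxy and the propoxy.

The compounds shown leave open whether methoxy or a longer chain such as butoxy would narrow or widen the remaining gap to compound 1. They also leave open how an amine or a carboxylic acid on the same aromatic carbon would compare.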